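The compounds below may be only part of what the source reports. "The series", "measured", "known", "first", "only" and "open" are said of these compounds alone.

Measured in a functional assay on HeLa cells (Homo sapiens) for antiproliferative activity, read by MTT assay, with a stated time of 48 h; on this read-out lower numbers stand for stronger inhibition and higher numbers for weaker inhibition:
- Compound 1 `CN(C)CCCCn1c(N)c(C#N)c2nc(C#N)c(C#N)nc21`: > 50000 nM, a limit of the assay and not a number
- Compound 2 `CN(C)CCCn1c(N)c(-c2nc3ccccc3o2)c2nc(C#N)c(C#N)nc21`: 11200 nM
- Compound 3 `N#Cc1nc2c(-c3nc4ccccc4o3)c(N)n(CCCN3CCCCC3)c2nc1C#N`: 12200 nM

Among the measured compounds shown here, compound 3, at 12200 nM, lies within the scatter of compound 2, at 11200 nM, and these are the only two actual numbers so far. The next structure is compound 4 `CN(C)CCCCn1c(N)c(-c2nc3ccccc3o2)c2nc(C#N)c(C#N)nc21`, and the difference from compound 3 is as follows: (dimethylamino)methyl in place of piperidin-1-yl on a saturated chain carbon, three bonds along the chain from an aromatic nitrogen. Put another way, 3-(piperidin-1-yl)propyl gives way to 4-(dimethylamino)butyl.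

For the measured compounds named here, one measured step bears on this change: a 1.1-fold higher number from compound 2 to compound 3 (0.04 log units; within the scatter), with piperidin-1-yl in place of dimethylamino on the chain. That exchange of end groups made no difference beyond the scatter. The step from 3-(dimethylamino)propyl to 4-(dimethylamino)butyl has not been measured on its own. Compound 4 shares the 4-(dimethylamino)butyl group with compound 1, which differs elsewhere on the core. Compound 1 gave only a limit, > 50000 nM.

With so little to go on, no shift beyond the scatter is expected in this assay, though the range must stay wide. The expected size is a 1.1-fold lower number from compound 3 to compound 4 (0.04 log units; within the scatter). For compound 4 the estimated value is 11000 nM, with an expected range from 4500 nM to 30000 nM.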

Compound 4, half-maximal inhibitory concentration: 1950 nM
Beside the measured number, compound 4's estimate is 5.6-fold (0.75 log units) above it; measured number below the stated range.
By their numbers in this assay, from the lowest: compound 4; then compounds 2 and 3 (each within the scatter of the next). At a limit, above all of these: compound 1.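

In this assay the length of the chain proves to matter where the exchange of end groups on the shorter chain did not: the change in the 3-(dimethylamino)propyl to 4-(dimethylamino)butyl comparison is a 5.7-fold lower number from compound 2 to compound 4 (0.76 log units; beyond the scatter) with the dimethylamino end kept, and the full change from 3-(piperidin-1-yl)propyl to 4-(dimethylamino)butyl is a 6.3-fold lower number from compound 3 to compound 4 (0.80 log units; beyond the scatter) on the same shared core. The 4-(dimethylamino)butyl chain does not give this result by itself, since the comparison with 1,3-benzoxazol-2-yl in place of cyano on an aromatic carbon is an at least 25-fold lower number from compound 1 to compound 4 (1.40 log units; beyond the scatter) and the chain is the same on both sides. That last step rests on a limit of the assay and not on a number, which is what compound 1 gives: the limit of > 50000 nM in this assay, at which 1 of the 4 values shown sits.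

The compounds shown leave open whether a longer chain, such as 5-(dimethylamino)pentyl, would lower the number further or raise it again. They also leave open whether 4-(piperidin-1-yl)butyl would match 4-(dimethylamino)butyl, and how a morpholine or a primary amine at the chain end would read.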